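Ether for Amine on the Nitro-Bearing Sulfonamide Arm

A few compounds are considered here, and "the series" means these few. Any claim that something is new, unique, unknown or untested is made for them only; others in the source may bear on it.

Compound 1 `CC1(C)CCC(CN2CCN(c3ccc(C(=O)NS(=O)(=O)c4ccc(NCC5CCOCC5)c([N+](=O)[O-])c4)c(Oc4cnc5[nH]ccc5c4)c3)CC2)=C(c2ccc(Cl)cc2C(F)(F)F)C1`: 0.86 nM
Compound 2 `CN1CCC(CNc2ccc(S(=O)(=O)NC(=O)c3ccc(N4CCN(CC5=C(c6ccc(C(F)(F)F)cc6)CC(C)(C)CC5)CC4)cc3Oc3cnc4[nH]ccc4c3)cc2[N+](=O)[O-])C1`: 2.4 nM
Compound 3 `CC(C)C(=O)N1CCC(CNc2ccc(S(=O)(=O)NC(=O)c3ccc(N4CCN(CC5=C(c6ccc(C(F)(F)F)cc6)CC(C)(C)CC5)CC4)cc3Oc3cnc4[nH]ccc4c3)cc2[N+](=O)[O-])CC1`: 2.4 nM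

In an assay on isolated protein for displacement of a labelled ligand from Apoptosis regulator Bcl-2 (Homo sapiens), with a stated time of 15 min (a higher number here means a weaker inhibitor, a lower number a stronger inhibitor), compound 2 gives 2.4 nM, level with compound 3 and together with it the highest number of the three, while compound 1 gives the lowest. Compound 4 `CC1(C)CCC(CN2CCN(c3ccc(C(=O)NS(=O)(=O)c4ccc(OCC5CCOCC5)c([N+](=O)[O-])c4)c(Oc4cnc5[nH]ccc5c4)c3)CC2)=C(c2ccc(C(F)(F)F)cc2)C1` differs from compound 2 by (oxan-4-yl)methoxy in place of ((1-methylpyrrolidin-3-yl)methyl)amino on an aromatic carbon. Among the compounds with values here, one measured step touches this arm: no change at the digits printed from compound 2 to compound 3 (within the scatter), where one saturated ring on the amino-linked chain replaced another. Within the data shown here, no measured pair exchanges the amino attachment for an ether. Compound 1 carries an (oxan-4-yl)methyl chain on an amino attachment but also differs in its aryl group, so its value alone shows only that the oxane chain is tolerated. Compound 4 is therefore expected to stay close to compound 2, with a 1.3-fold higher number from compound 2 to compound 4 (0.10 log units; within the scatter), estimated at 3 nM within 1 nM to 10 nM.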

Compound 4, half-maximal inhibitory concentration: 1 nM
Compound 4: the middle estimate sits 3.0-fold (0.48 log units) above what was measured, within the range that was stated.
By their numbers in this assay, from the lowest: compounds 1 and 4 (each within the scatter of the next); then compounds 2 and 3 (each within the scatter of the next).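

On this aromatic carbon, ortho to a nitro group, (oxan-4-yl)methoxy in place of ((1-methylpyrrolidin-3-yl)methyl)amino gives a 2.4-fold lower number from compound 2 to compound 4 (0.38 log units; beyond the scatter) in this assay and so the position retains binding without an amino attachment. This is the only step on this arm shown to lie beyond the scatter, but the attachment atom and the saturated ring change together, so neither can be credited alone. Nothing measured here accounts for the step. Going by these compounds, it remains open how a 1-methylpyrrolidin-3-yl ring would behave on the ether attachment, and whether a morpholine ring or a longer chain would be accepted there.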